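Hydrazide series: heteroaryl exchange on the acyl carbonyl

The source may hold more compounds than are shown below. What is called first, only, known or untested is meant among the compounds shown, and "the series" means these compounds.

Among the measured compounds shown here, compound 1 `O=C(COc1c(F)cc(C(=O)c2ccc(F)cc2)cc1Cl)NNC(=O)c1ccc(=O)oc1` is one of two compounds measured in a functional assay on MCF7 cells (Homo sapiens) for cytotoxicity, read by LDH release, with a stated time of 48 h; a lower number here means a stronger inhibitor, a higher number a weaker inhibitor. In this assay compound 1 gives 61100 nM, the highest of the two numbers. Compound 2 `Cc1ccc(C(=O)c2cc(F)c(OCC(=O)NNC(=O)c3ccc(=O)oc3)c(Cl)c2)cc1` is its nearest neighbour; in this assay compound 2 gives 24200 nM. For the measured compounds named here, the only measured step, a 2.5-fold lower number from compound 1 to compound 2 (0.40 log units; beyond the scatter), concerns methyl in place of fluoro on an aromatic carbon.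

Compound 3 `Cn1cnc(C(=O)NNC(=O)COc2c(F)cc(C(=O)c3ccc(F)cc3)cc2Cl)c1` differs from compound 1 in a different part of the structure: a group of 6 heavy atoms (4 carbon, 2 nitrogen; one five-membered aromatic ring with 2 hetero atoms) in place of a group of 7 heavy atoms (5 carbon, 2 oxygen; one six-membered aromatic ring with 1 hetero atom), on a carbonyl carbon. Going by the values given here, no measured step touches the group on the carbonyl carbon whose other neighbour is the amide-type nitrogen, so the single step on record gives no direct guide to this change; it shows only that one small replacement elsewhere moved the number modestly. With nothing to support a shift in either direction, the expected step in this assay is none beyond the scatter, carrying wide uncertainty. Compound 3 is therefore estimated at 50000 nM in this assay, within a range from 18000 nM to 140000 nM, which corresponds to an expected step of a 1.2-fold lower number from compound 1 to compound 3 (0.09 log units; within the scatter).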

Compound 3, half-maximal inhibitory concentration: 44600 nM
The estimate for compound 3 lay 1.1-fold (0.05 log units) above the measured number; the measured number falls inside the stated range.
By their numbers in this assay, from the lowest: compounds 2, 3 and 1 (each within the scatter of the next, the first and the last beyond it).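

Notes on the acyl side of the hydrazide: in this assay the exchange on the carbonyl carbon whose other neighbour is the amide-type nitrogen gives a 1.4-fold lower number from compound 1 to compound 3 (0.14 log units; within the scatter) and this is the first reading at this position, where the earlier pair spoke only to the methyl and fluoro replacement on an aromatic carbon. In this single pair, the five-membered ring of 1-methyl-1H-imidazol-4-yl stands in for the six-membered ring of the leaving group, with nitrogen hetero atoms in place of oxygen and no double bond outside aromatic rings, yet the step stays within the scatter. The position therefore accepts this particular heteroaryl exchange with no readable shift in the number, although nothing on record accounts for that outcome.

Still open, on these data alone, is whether any group on this carbonyl carbon moves the number beyond the scatter, for example an unsubstituted phenyl, a carboxylic acid or a longer alkyl chain carrying an amine. Also open, as far as these compounds go, is whether the methyl in place of fluoro step carries over to compounds bearing 1-methyl-1H-imidazol-4-yl.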